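The source may report more compounds than this note shows. Statements on the series, on what has been measured and on what is new or still open speak of the compounds shown alone.

Measured compounds, with their values:

- compound 1, `O=C(Nc1cccc(-c2oc3cc(-c4ccc(F)cc4)ccc3c(=O)c2O)c1)c1ccccc1F`: 4410 nM
- compound 2, `O=C(Nc1cccc(-c2oc3cc(-c4ccc(F)cc4)ccc3c(=O)c2O)c1)c1ccc(Cl)cc1`: 10800 nM
- compound 3, `O=C(Nc1cccc(-c2oc3cc(-c4ccc(F)cc4)ccc3c(=O)c2O)c1)c1ccc(F)cc1F`: 20500 nM

In a functional assay on A549 cells (Homo sapiens) for antiproliferative activity, read by CCK-8 assay, with a stated time of 72 h (on this read-out lower numbers stand for stronger inhibition and higher numbers for weaker inhibition), compound 1 gives the lowest number of the three: compound 2 lies a 2.4-fold higher number from compound 1 to compound 2 (0.39 log units; beyond the scatter) away, and compound 3 a 4.6-fold higher number from compound 1 to compound 3 (0.67 log units; beyond the scatter) away. Compound 4, `O=C(Nc1cccc(-c2oc3cc(-c4ccc(F)cc4)ccc3c(=O)c2O)c1)c1cccc(F)c1`, differs from compound 1 only in 3-fluorophenyl in place of 2-fluorophenyl on a carbonyl carbon. Among the compounds with values here, no measured step moves the fluorine around the ring in this way; the nearest guides are a 2.4-fold higher number from compound 1 to compound 2 (0.39 log units; beyond the scatter) and a 4.6-fold higher number from compound 1 to compound 3 (0.67 log units; beyond the scatter), both changes to the same group that raised the number modestly. A modest rise is therefore expected for compound 4 as well, though a result within the scatter is also plausible. Compound 4 is estimated at 7000 nM, within 2500 nM to 20000 nM, which means an expected step of a 1.6-fold higher number from compound 1 to compound 4 (0.20 log units; within the scatter).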

Compound 4, half-maximal inhibitory concentration: 15400 nM
Compound 4: the middle estimate sits 2.2-fold (0.34 log units) below what was measured; the range from low to high includes it.
By their numbers in this assay, from the lowest: compound 1; then compounds 2, 4 and 3 (each within the scatter of the next).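

Swapping 2-fluorophenyl for 3-fluorophenyl on the carbonyl carbon keeps the same atoms and only shifts the fluorine, yet it gives a clear change in this assay (a 3.5-fold higher number from compound 1 to compound 4 (0.54 log units; beyond the scatter)). Compound 4 stays close to the other two analogues (a 1.3-fold lower number from compound 3 to compound 4 (0.12 log units; within the scatter); a 1.4-fold higher number from compound 2 to compound 4 (0.15 log units; within the scatter)), so among these four only compound 1, with 2-fluorophenyl, stands apart. Still open, from the compounds shown here alone, is whether 2-chlorophenyl or 2-methoxyphenyl would match 2-fluorophenyl, or whether the fluorine itself is needed at that spot. Nothing measured here gives a reason for the difference.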